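Replacing sulfanyl with (3-hydroxypropyl)amino on the shared core

This account rests on a few compounds, and the source may have more. Where it says the series, first, only, none or still open, it means among the compounds named here.

For the measured compounds named here, in a functional assay on K562 cells (Homo sapiens) for cytotoxicity (on this read-out lower numbers stand for stronger inhibition and higher numbers for weaker inhibition), the numbers so far are all high: compound 1 `CCC(CO)Nc1nc(NCc2ccccc2)c2nc(Cl)n(C(C)C)c2n1` gives 91000 nM, compound 2 `CCC(CO)Nc1nc(NCc2ccccc2)c2nc(O)n(C(C)C)c2n1` gives 74000 nM, and compound 3 `CCC(CO)Nc1nc(NCc2ccccc2)c2nc(S)n(C(C)C)c2n1` gives 154000 nM. Compound 3 cannot be separated from compound 1, with a 1.7-fold higher number from compound 1 to compound 3 (0.23 log units; within the scatter). Its gap to compound 2 is modest, with a 2.1-fold higher number from compound 2 to compound 3 (0.32 log units; beyond the scatter).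

Compound 4 `CCC(CO)Nc1nc(NCc2ccccc2)c2nc(NCCCO)n(C(C)C)c2n1` has (3-hydroxypropyl)amino in place of sulfanyl on an aromatic carbon. Going by the values given here, the steps that bear on this change are the exchanges at that same carbon. Besides the two above, they include a 1.2-fold lower number from compound 1 to compound 2 (0.09 log units; within the scatter). All three are small, so this carbon has shown little response so far. Among the compounds with values here, each of them swaps one small group for another, however, and no measured compound carries a chain there, so the range has to stay wide.

No step beyond the scatter is expected in this assay, and the estimated step is a 1.5-fold lower number from compound 3 to compound 4 (0.19 log units; within the scatter). Compound 4 is expected at 100000 nM, with an estimated range of 40000 nM to 220000 nM.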

Compound 4, half-maximal inhibitory concentration: 30000 nM
Compound 4: middle estimate off by 3.3-fold (0.52 log units), on the high side; the whole stated range lies above it.
By their numbers in this assay, from the lowest: compound 4; then compounds 2, 1 and 3 (each within the scatter of the next, the first and the last beyond it).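

In this assay this carbon proves responsive once a chain sits on it: (3-hydroxypropyl)amino stands apart from all three small groups, with a 5.1-fold lower number from compound 3 to compound 4 (0.71 log units; beyond the scatter) and a 3.0-fold lower number from compound 1 to compound 4 (0.48 log units; beyond the scatter) and a 2.5-fold lower number from compound 2 to compound 4 (0.39 log units; beyond the scatter) and each of these steps lies beyond the scatter. Among chloro, hydroxy and sulfanyl, only the exchange of hydroxy for sulfanyl passed the scatter, so compound 4 is the first to stand clear of all the others, although compound 4 at 30000 nM remains a high number. Nothing available here accounts for this step.

As far as these compounds go, it remains open whether the step follows the ring-bound amine nitrogen, the propyl chain or its terminal hydroxy group. A plain amino group, an unsubstituted propylamino chain and a longer hydroxyalkylamino chain at this carbon would separate these parts.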